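This account rests on a few compounds, and the source may have more. Where it says the series, first, only, none or still open, it means among the compounds named here.

In an assay on CHO cells for agonist activity at Neuronal acetylcholine receptor; alpha3/alpha6/beta2/beta3 (Homo sapiens), read by FLIPR and calcium flux (a lower number here means a smaller maximal response, a higher number a larger maximal response), compound 2 `O=C([C@@H]1C[C@H]1F)N1CC2CC(C1)N2` gives 130%, the higher of the two numbers seen so far; compound 1 `CC(C)C(=O)N1CC2CC(C1)N2` gives 45%. Going by the values given here, the only measured step, a number 85 percentage points higher from compound 1 to compound 2 (beyond the scatter), exchanged isopropyl for the ring and fluorine together. Compound 3 `C[C@H]1C[C@@H]1C(=O)N1CC2CC(C1)N2` keeps the three-membered ring and changes only (2-methylcyclopropyl in place of 2-fluorocyclopropyl on a carbonyl carbon). That step is not covered by any measured pair, so a moderate drop in this assay is expected for compound 3, roughly a number 30 percentage points lower from compound 2 to compound 3 (beyond the scatter), with wide uncertainty. For compound 3 the estimate in this assay is 100%, between 60% and 140%.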

Compound 3, largest response reached (Emax), in percent of the reference or control that the assay uses: 64%
Estimate against measurement, compound 3: 36 percentage points above; the range from low to high includes it.
By their numbers in this assay, from the lowest: compound 1; then compound 3; then compound 2.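

Swapping 2-fluorocyclopropyl for 2-methylcyclopropyl in this assay gives a number 66 percentage points lower from compound 2 to compound 3 (beyond the scatter) even though the ring and the heavy-atom count stay the same, so at this position on a carbonyl carbon the ring alone does not set the maximal response; the group on the ring matters too. The ring with methyl still gives a number 19 percentage points higher from compound 1 to compound 3 (beyond the scatter) when set against isopropyl, a much smaller rise than the one seen with fluorine. No evidence at hand explains the gap between fluorine and methyl.

Still open, on these data alone, is where plain cyclopropyl would fall relative to these two substituted rings. Also open, as far as these compounds go, is whether a larger group on the ring, such as 2-chlorocyclopropyl or 2-trifluoromethylcyclopropyl, would follow the fluorine or the methyl.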